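The compounds below may be only part of what the source reports. "The series", "measured", "known", "first", "only" and "open" are said of these compounds alone.

Of the compounds shown here, three have numbers so far in a physicochemical assay for solubility, read by HPLC, in phosphate buffer, measured as kinetic solubility, at pH 7.4; on this read-out lower numbers stand for lower solubility and higher numbers for higher solubility. Compound 1 (`CCC(=O)c1cc(-c2ccc(Cl)cc2)n(-c2cccc(S(N)(=O)=O)c2)c1C`) gives 200 nM, compound 2 (`NS(=O)(=O)c1ccc(-c2cc(C(=O)C3CCCC3)nn2-c2ccc(Cl)cc2)cc1`) gives 4600 nM, and compound 3 (`CCC(=O)c1cc(-c2ccc(S(N)(=O)=O)cc2)n(-c2ccccc2)n1`) gives 47200 nM. Compound 2 therefore stands in the middle of the three, and its gaps to both of the others lie beyond the usual scatter of repeated measurements. No two of these compounds differ in only one place, so none of these gaps can be tied to a single structural change.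

Compound 4 (`CN(C(=O)c1cc(-c2ccc(S(N)(=O)=O)cc2)n(-c2ccc(Cl)cc2)n1)C1CC(F)(F)C1`) has not yet been measured, and it differs from compound 2 in one place: (3,3-difluorocyclobutyl)(methyl)amino in place of cyclopentyl on a carbonyl carbon. In words, (3,3-difluorocyclobutyl)(methyl)amino takes the place of cyclopentyl on a carbonyl carbon, so cyclopentylcarbonyl becomes (3,3-difluorocyclobutyl)(methyl)carbamoyl.

For the measured compounds named here, no measured pair shows what this exchange does, so the data give no firm direction. The best starting point is the closest measured compound, compound 2 at 4600 nM, and no step beyond the scatter is expected. The expected step, a 1.2-fold lower number from compound 2 to compound 4 (0.06 log units; within the scatter), is accordingly small, though uncertain. The estimate for compound 4 is 4000 nM, with an expected range from 800 nM to 20000 nM.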

Compound 4, solubility: 30900 nM
Beside the measured number, compound 4's estimate is 7.7-fold (0.89 log units) below it; measured number above the stated range.
By their numbers in this assay, from the lowest: compound 1; then compound 2; then compounds 4 and 3 (each within the scatter of the next).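

For the compounds shown here, the read-out here is this assay and on it, the place on a carbonyl carbon held by cyclopentyl in compound 2 proves open to a large shift: (3,3-difluorocyclobutyl)(methyl)amino in that place gives a 6.7-fold higher number from compound 2 to compound 4 (0.83 log units; beyond the scatter) and this is the first gap that can be tied to a single structural change. The exchange alters several things at once, turning cyclopentylcarbonyl into (3,3-difluorocyclobutyl)(methyl)carbamoyl and bringing in nitrogen, fluorine and a four-membered ring in place of a five-membered one. Nothing measured here explains why the number rises.

This single pair cannot show which of those alterations carries the step, and a plain cyclobutyl(methyl)amino group without fluorine, or a small dimethylamino group, would begin to separate them. As far as these compounds go, whether the same exchange gives a similar step on a different core, such as that of compound 1, also remains open.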